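A few compounds are considered here, and "the series" means these few. Any claim that something is new, unique, unknown or untested is made for them only; others in the source may bear on it.

In a functional assay on HepG2 cells (Homo sapiens) for cytotoxicity, read by spectrophotometry, with a stated time of 72 h (on this read-out higher numbers stand for weaker inhibition and lower numbers for stronger inhibition), compound 1 `COc1ccc(-c2cccc(=O)n2-c2cc(OC)c(OC)c(OC)c2)cc1O` reads < 10 nM, which is a limit of the assay and not a number. Compound 2 `COc1ccc(-c2cccc(=O)n2-c2cc(OC)c(OC)c(OC)c2)cc1OC` gives 513 nM. Compound 3 `COc1cc(-n2c(-c3ccncc3)cccc2=O)cc(OC)c1OC` gives 1780 nM, the higher of the two actual numbers in this small set.

The next structure is compound 4 `COc1ccc(-c2cccc(=O)n2-c2cc(OC)c(OC)c(OC)c2)cc1C`, not yet measured. The change is 4-methoxy-3-methylphenyl in place of pyridin-4-yl on an aromatic carbon, which restores a six-membered aromatic ring of carbon only at the position where compound 3 carries pyridin-4-yl.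

Among the compounds with values here, two measured steps bear on this. Placing pyridin-4-yl in place of 3-hydroxy-4-methoxyphenyl gave an at least 170-fold higher number from compound 1 to compound 3 (2.25 log units; beyond the scatter). Methyl in place of hydrogen on an oxygen gave an at least 51-fold higher number from compound 1 to compound 2 (1.71 log units; beyond the scatter). Compound 4 has no hydroxy group, so compound 2 at 513 nM is a closer guide than compound 1.

A clear move to a lower number is expected, of a size beyond the scatter: a 7.1-fold lower number from compound 3 to compound 4 (0.85 log units; beyond the scatter). The estimate for compound 4 is 250 nM, with an expected range of 50 nM to 1100 nM.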

Compound 4, half-maximal inhibitory concentration: 129 nM
Compound 4: the middle estimate sits 1.9-fold (0.29 log units) above what was measured; the measured number falls inside the stated range.
By their numbers in this assay, from the lowest: compound 4; then compound 2; then compound 3. At a limit, below all of these: compound 1.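

In this assay, the gain over pyridin-4-yl does not depend on a hydroxy group: 4-methoxy-3-methylphenyl in its place gives a 14-fold lower number from compound 3 to compound 4 (1.14 log units; beyond the scatter). The small group on that phenyl ring still matters without a hydroxy, with methyl in place of methoxy giving a 4.0-fold lower number from compound 2 to compound 4 (0.60 log units; beyond the scatter), while methyl in place of hydroxy gives an at least 12-fold higher number from compound 1 to compound 4 (1.11 log units; beyond the scatter), so the hydroxy of compound 1 remains the best of these three groups. Compound 1 reads as a limit of the assay and not a number, so the full size of that last step stays unknown: the limit of < 10 nM in this assay, at which 1 of the 4 values shown sits.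

From the compounds shown here alone, how an amine, a fluorine or an ethyl group would read in place of this methyl stays open. Pyridin-4-yl is also the only ring with a nitrogen at this place, so a pyridine ring carrying the same methoxy and methyl groups remains an open case.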